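Oxazoline for thiazoline on the sulfonylmethyl side chain

The compounds below may be only part of what the source reports. "The series", "measured", "known", "first", "only" and "open" are said of these compounds alone.

Measured so far:
compound 1 `Cc1ccc(-c2c[nH]nc2S(=O)(=O)CC2=NCCS2)cc1`, in a functional assay, read by Griess assay, with a stated time of 150 min, tested at 50 ug/mL (on this read-out lower numbers stand for a weaker effect and higher numbers for a stronger effect at the one concentration tested), compound 1 is reported as "not active" (no number reported)
compound 2 `COc1ccc(C2=NOC(c3ccc(C)cc3)C2S(=O)(=O)CC2=NCCO2)cc1`, compound 2 gives 61.9%
compound 3 `COc1ccc(C2=NOC(c3ccc(C)cc3)C2S(=O)(=O)CC2=NCCS2)cc1`, compound 3 gives 48.6%

Compound 2 and compound 3 share one core and differ only by a group of 5 heavy atoms (3 carbon, 1 nitrogen, 1 oxygen; one five-membered non-aromatic ring with 2 hetero atoms) in place of a group of 5 heavy atoms (3 carbon, 1 nitrogen, 1 sulfur; one five-membered non-aromatic ring with 2 hetero atoms), on a saturated chain carbon bound to a sulfonyl sulfur; this single change gave a number 13.3 percentage points higher from compound 3 to compound 2 (beyond the scatter). Compound 1 carries a different core; the difference between the two cores is not broken down here, and for compound 1 only the report "not active" (no number reported) stands, not a number.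

Compound 4 `Cc1ccc(-c2c[nH]nc2S(=O)(=O)CC2=NCCO2)cc1` is not yet measured. Going by the values given here, it differs from compound 1 by a group of 5 heavy atoms (3 carbon, 1 nitrogen, 1 oxygen; one five-membered non-aromatic ring with 2 hetero atoms) in place of a group of 5 heavy atoms (3 carbon, 1 nitrogen, 1 sulfur; one five-membered non-aromatic ring with 2 hetero atoms), on a saturated chain carbon bound to a sulfonyl sulfur, which is the same change, at the same place, as the one from compound 3 to compound 2. Among the compounds with values here, a step of similar size, about a number 13.3 percentage points higher from compound 3 to compound 2 (beyond the scatter), is expected from compound 1 to compound 4, because the step of a number 13.3 percentage points higher from compound 3 to compound 2 (beyond the scatter) is the only measured instance of this change. Going by these compounds, as compound 1 gave no number, the starting point is unknown and a low outcome, or again no number, is likely. Compound 4 is estimated at 15%, expected between 0% and 35%.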

Compound 4, a percentage reported as activity, at one concentration (the size of the read-out at that concentration, not a potency): 59.4%
Estimate against measurement, compound 4: 44.4 percentage points below; measured number outside the range, above it.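

Going by these compounds alone, no step from compound 1 to compound 4 can be read: compound 1 stands as "not active" (no number reported) without a number, while compound 4 gives 59.4%. The compounds shown leave open how large the oxazoline-for-thiazoline change is on the core of compound 1, and whether it matches a number 13.3 percentage points higher from compound 3 to compound 2 (beyond the scatter). No measured evidence bears on this result.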